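Aryl fluorination of a cyclopropylmethyl-substituted modulator

A few compounds are considered here, and "the series" means these few. Any claim that something is new, unique, unknown or untested is made for them only; others in the source may bear on it.

Compound 3 `N#Cc1c(N2CCC(c3ccccc3)CC2)ccn(CC2CC2)c1=O` is the reference point. In a functional assay on CHO cells for positive allosteric modulation of metabotropic glutamate receptor 2 (Homo sapiens), with a stated time of 30 min (on this read-out lower numbers stand for smaller maximal responses and higher numbers for larger maximal responses), compound 3 gives 309%, which is the second highest of the three values: compound 2 `CC(C)Cn1ccc(N2CCC(c3ccccc3)CC2)c(C#N)c1=O` gives 316%, and the change a number 7 percentage points lower from compound 2 to compound 3 (within the scatter) lies within the scatter, while compound 1 `CC(C)CCn1ccc(N2CCC(c3ccccc3)CC2)c(C#N)c1=O` gives 268%, so that a number 41 percentage points higher from compound 1 to compound 3 (beyond the scatter) is a large rise. Compound 4 `N#Cc1c(N2CCC(c3cccc(F)c3)CC2)ccn(CC2CC2)c1=O` differs from compound 3 only in fluoro in place of hydrogen on an aromatic carbon. Within the data shown here, none of the measured steps bears directly on this change; all three concern the chain on the aromatic nitrogen. For compound 4, the step of a number 9 percentage points lower from compound 3 to compound 4 (within the scatter) is therefore expected to stay within the scatter, and compound 4 is estimated to give 300% in this assay, in the range from 250% to 350%.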

Compound 4, largest response reached (Emax), in percent of the reference or control that the assay uses: 268%
The estimate for compound 4 lay 32 percentage points above the measured number, and the stated range covers the measured number.
By their numbers in this assay, from the lowest: compounds 1 and 4 (each within the scatter of the next); then compounds 3 and 2 (each within the scatter of the next).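

Among these compounds, on the phenyl ring, a position the earlier steps did not touch, the read-out in this assay proves sensitive to a single heavy atom: phenyl to 3-fluorophenyl gives a number 41 percentage points lower from compound 3 to compound 4 (beyond the scatter) and so counts as a large step. The chain on the aromatic nitrogen is therefore not the only place where a small change moves the maximal response. Nothing available accounts for this step.

The compounds shown leave open how a chlorine atom or a methoxy group would behave at this aromatic carbon. They also leave open whether fluoro on the ring would give a similar step alongside the isobutyl chain of compound 2 or the longer chain of compound 1.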